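The source may report more compounds than this note shows. Statements on the series, on what has been measured and on what is new or still open speak of the compounds shown alone.

Working notes on the series. Three compounds have numbers in a functional assay on RPMI-8226 cells (Homo sapiens) for inhibition, read by sulforhodamine B assay, with a stated time of 48 h; a lower number here means a stronger inhibitor of growth, a higher number a weaker inhibitor of growth. Compound 1 `O=C(Nc1cccc(-n2cc(-c3ccncc3)c(-c3ccc(Cl)c(O)c3)n2)c1)Nc1cccc(C(F)(F)F)c1` gives 1340 nM, compound 2 `COc1cc(-c2nn(-c3cccc(NC(=O)Nc4cc(C(F)(F)F)cc(C(F)(F)F)c4)c3)cc2-c2ccncc2)ccc1Cl` gives 307 nM, and compound 3 `COc1cc(-c2nn(-c3cccc(NC(=O)c4cccc(C(F)(F)F)c4)c3)cc2-c2ccncc2)ccc1Cl` gives 1570 nM. Compound 3 stands highest of the three; compound 1 is within the scatter of it, while compound 2 lies beyond the scatter, with the lower number. The next compound, compound 4 `COc1cc(-c2nn(-c3cccc(NC(=O)Nc4ccc(Cl)c(Cl)c4)c3)cc2-c2ccncc2)ccc1Cl`, differs from compound 3 in one place: (3,4-dichlorophenyl)amino in place of 3-(trifluoromethyl)phenyl on a carbonyl carbon. Among the compounds with values here, no measured pair isolates this change. Compound 2 carries a urea and gives 307 nM, which is taken as grounds for expecting a step down of moderate size in this assay, a 2.9-fold lower number from compound 3 to compound 4 (0.46 log units; beyond the scatter). Compound 4 is therefore estimated at 550 nM, with a range from 200 nM to 1500 nM.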

Compound 4, concentration for 50% growth inhibition: 388 nM
The estimate for compound 4 lay 1.4-fold (0.15 log units) above the measured number; the measured number falls inside the stated range.
By their numbers in this assay, from the lowest: compounds 2 and 4 (each within the scatter of the next); then compounds 1 and 3 (each within the scatter of the next).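

In this assay, (3,4-dichlorophenyl)amino in place of 3-(trifluoromethyl)phenyl on this carbonyl carbon gives a 4.0-fold lower number from compound 3 to compound 4 (0.61 log units; beyond the scatter), a step beyond the scatter and the only measured one at this position. The change replaces (3-(trifluoromethyl)phenyl)carbonyl with (3,4-dichlorophenyl)carbamoyl, so the added amino nitrogen and the altered ring substituents arrive together, and this step cannot separate them. Nothing available explains the step.

Still open, going by these compounds, is whether 3,4-dichlorophenyl placed directly on the carbonyl carbon, without the amino nitrogen, keeps the lower number, and whether a cyclohexylamino group does so in the same place.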